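Swapping the aryl group on the alkenyl chain: compound 4

The compounds below may be only part of what the source reports. "The series", "measured", "known", "first", "only" and "open" are said of these compounds alone.

Measured compounds in a functional assay on HL-60 cells (Homo sapiens) for cytotoxicity, read by WST assay, with a stated time of 48 h; on this read-out higher numbers stand for weaker inhibition and lower numbers for stronger inhibition:
- compound 1 `COc1ccc(/C=C/C[C@H]2C[C@@H]([C@@H](O)c3ccccc3)CO[C@@H]2c2ccccc2)cc1` gives 9010 nM
- compound 2 `COc1ccccc1/C=C/C[C@H]1C[C@@H]([C@@H](O)c2ccccc2)CO[C@@H]1c1ccccc1` gives 10100 nM
- compound 3 `O=[N+]([O-])c1ccc(/C=C/C[C@H]2C[C@@H]([C@@H](O)c3ccccc3)CO[C@@H]2c2ccccc2)cc1` gives 4880 nM

All three share the same core and differ only in the aryl group carried on the double-bonded chain carbon. Compound 3 has the lowest number of the three, but its separation from the others is small: a 1.8-fold lower number from compound 1 to compound 3 (0.27 log units; within the scatter) and a 2.1-fold lower number from compound 2 to compound 3 (0.32 log units; beyond the scatter), so it cannot be called clearly the strongest. The step from compound 1 to compound 2, a 1.1-fold higher number from compound 1 to compound 2 (0.05 log units; within the scatter), shows that moving the methoxy group around the ring changes nothing beyond the scatter.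

Compound 4 `O[C@@H](c1ccccc1)[C@H]1CO[C@H](c2ccccc2)[C@@H](C/C=C/c2ccccc2F)C1` is the next compound in this series. Its change from compound 3 is 2-fluorophenyl in place of 4-nitrophenyl on a double-bonded chain carbon bound to a double-bonded chain carbon. Among the measured compounds shown here, no measured step involves a fluorophenyl group, so the two steps toward compound 3 are the only guides, and both are small. The expectation is therefore a step back toward the numbers of compound 1 and compound 2: a 1.6-fold higher number from compound 3 to compound 4 (0.21 log units; within the scatter). Compound 4 is estimated at 8000 nM, in a range from 3500 nM to 18000 nM.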

Compound 4, half-maximal inhibitory concentration: 9530 nM
The estimate for compound 4 lay 1.2-fold (0.08 log units) below the measured number; low and high end bracket the measured number.
By their numbers in this assay, from the lowest: compounds 3, 1, 4 and 2 (each within the scatter of the next, the first and the last beyond it).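

In this assay, the 2-fluorophenyl group at this place on the chain cannot be told apart from either methoxy-bearing ring, with a 1.1-fold lower number from compound 2 to compound 4 (0.03 log units; within the scatter) and a 1.1-fold higher number from compound 1 to compound 4 (0.02 log units; within the scatter) as the steps. Even the step away from the 4-nitrophenyl group stays small (a 2.0-fold higher number from compound 3 to compound 4 (0.29 log units; within the scatter)), so a ring with fluoro in place of nitro or methoxy adds a fourth aryl group without opening a clear gap, and only compound 2 and compound 3 remain separated beyond the scatter. Nothing available here explains these numbers.

Still open, going by these compounds, is whether an aryl ring carrying an amine or a carboxylic acid would move the number clearly beyond this narrow band. A longer chain between the double bond and the aryl ring also remains to be judged at this place.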